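A Methyl on the Phenyl Ring of Compound 1

The compounds below may be only part of what the source reports. "The series", "measured", "known", "first", "only" and "open" are said of these compounds alone.

Compound 1 `Cc1ccc(S(=O)(=O)Oc2ccc3c(c2C)[C@H](Cn2cc(-c4ccccc4)nn2)[C@@]24CC(=O)[C@@](C)(CC[C@@H]32)C4)cc1` was examined in a functional assay on SW480 cells (Homo sapiens) for cytotoxicity, read by MTT assay, with a stated time of 4 days; a higher number here means a weaker inhibitor, a lower number a stronger inhibitor. In this assay compound 1 gave > 20000 nM, which is a limit of the assay and not a number. A second compound in the set, compound 2 `C=C1C[C@]23C[C@@]1(O)CC[C@@H]2c1cccc(C)c1[C@@H]3Cn1cc(-c2ccc(F)cc2)nn1`, was run in the same test. In this assay compound 2 gave > 20000 nM, again a limit and not a number. Where compound 1 stands is therefore told only by the limit of > 20000 nM in this assay, at which 2 of the 2 values shown sit; no step between measured compounds can be read, because every value shown sits at the limit of > 20000 nM in this assay, at which 2 of the 2 values shown sit.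

Compound 3 `Cc1ccc(-c2cn(C[C@H]3c4c(ccc(OS(=O)(=O)c5ccc(C)cc5)c4C)[C@@H]4CC[C@@]5(C)C[C@]43CC5=O)nn2)cc1` differs from compound 1 by methyl in place of hydrogen on an aromatic carbon. Among the measured compounds shown here, since the data give no measured step for comparison, the step of a number no higher from compound 1 to compound 3 (the limit leaves the size open) is expected to be none beyond the scatter of this assay, with no direction assigned. Compound 3 is accordingly expected to give about 20000 nM in this assay, within a range from 6000 nM to 60000 nM, and most probably the assay will again report only a limit.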

Compound 3, half-maximal inhibitory concentration: > 20000 nM
Compound 3 ended at the assay's limit (the forecaster's own chance of this, stated with the estimate: 80%); the middle value lies on the limit itself.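

In this assay compound 3 gave > 20000 nM as well, which is a limit of the assay and not a number. Among the compounds shown here, no step from compound 1 to compound 3 can be read, because both values sit at the same limit: the limit of > 20000 nM in this assay, at which 3 of the 3 values shown sit. The compounds shown leave open whether going from phenyl to 4-methylphenyl changes the half-maximal inhibitory concentration at all.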